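The compounds below may be only part of what the source reports. "The series", "measured", "known", "first", "only" and "open" are said of these compounds alone.

Measured so far:
compound 1, `Cc1ccc(S(=O)(=O)c2cnc3cc(F)ccc3c2N2CCC(C)CC2)cc1C`, which in an assay on isolated protein for displacement of a labelled ligand from metabotropic glutamate receptor 5 (Homo sapiens), with a stated time of 60 min, tested at 1 uM (a higher number here means more inhibition at the concentration tested (going by the name of the read-out), a lower number less inhibition), gives 90%
compound 2, `CC1CCN(c2c(S(=O)(=O)c3ccc(F)c(Cl)c3)cnc3cc(Cl)ccc23)CC1`, which in this assay gives 94%
compound 3, `Cc1ccc(S(=O)(=O)c2cnc3cc(F)ccc3c2N2CCC(C)CC2)cc1Cl`, which in this assay gives 93%

Compound 3 stands second of the three numbers, but the gaps to compound 2 on one side and to compound 1 on the other both fall within the usual scatter, so the three compounds cannot be told apart on these numbers.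

Compound 4, `CC1CCN(c2c(S(=O)(=O)c3ccc(F)c(F)c3)cnc3cc(F)ccc23)CC1`, differs from compound 3 in one place: 3,4-difluorophenyl in place of 3-chloro-4-methylphenyl on a sulfonyl sulfur. Among the measured compounds shown here, the one measured step that touches this phenyl ring is a number 3 percentage points higher from compound 1 to compound 3 (within the scatter), and it did not move the number beyond the scatter. Compound 2 also carries a halogen pair on this ring, a 3-chloro-4-fluorophenyl, together with a core that differs from the shared core of compounds 1 and 3, and in this assay compound 2 gives 94%, again in the same band. Nothing here points to a step beyond the scatter for compound 4, though the full exchange of chlorine and methyl for two fluorines goes a little further than any change measured so far.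

He therefore expects compound 4 to give about 88% in this assay, with a range from 72% to 97%. The step he expects is a number 5 percentage points lower from compound 3 to compound 4 (within the scatter).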

Compound 4, a percentage reported as inhibition, at one concentration (the size of the read-out at that concentration, not a potency): 94%
For compound 4 the middle estimate is 6 percentage points below the measured one, and the stated range covers the measured number.
By their numbers in this assay, from the lowest: compounds 1, 3, 2 and 4 (each within the scatter of the next).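

In this assay, the exchange of 3-chloro-4-methylphenyl for 3,4-difluorophenyl on a sulfonyl sulfur gives a number 1 percentage points higher from compound 3 to compound 4 (within the scatter), and the exchange of 3,4-dimethylphenyl for the same group gives a number 4 percentage points higher from compound 1 to compound 4 (within the scatter). Until now only one substituent on this phenyl had been changed within the shared core, whereas these steps replace both, and the number still stays within the scatter, so compound 1, compound 3 and compound 4 cannot be told apart at the single concentration tested. Nothing measured for these compounds accounts for this result.

The groups on a sulfonyl sulfur shown here are all phenyl rings bearing only methyl, chloro or fluoro, so it remains open whether a ring bearing a carboxylic acid, an amine or a methoxy group would keep the number in this band. The read-out is also the size of the inhibition at one concentration and not a potency, so any differences in potency among these compounds remain open as well.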